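A few compounds are considered here, and "the series" means these few. Any claim that something is new, unique, unknown or untested is made for them only; others in the source may bear on it.

The measured compounds, with their values in a functional assay (HSMC cells, Homo sapiens) for antiproliferative activity, with a stated time of 72 h; on this read-out higher numbers stand for weaker inhibition and lower numbers for stronger inhibition:
compound 1 `COC(=O)CNC(=O)c1ccc(OC[C@@H]2COc3ccccc3O2)cc1-c1ccccc1C` gives 700 nM;
compound 2 `COC(=O)CNC(=O)c1ccc(OC[C@@H]2COc3ccccc3O2)cc1-c1ccccc1OC` gives 35000 nM;
compound 3 `COC(=O)CNC(=O)c1ccc(C(=O)NC[C@H]2COc3ccccc3O2)cc1-c1ccccc1C` gives 113000 nM.

Compound 1 and compound 2 differ in one spot only: methoxy in place of methyl on an aromatic carbon. That single swap produced a 50-fold higher number from compound 1 to compound 2 (1.70 log units; beyond the scatter), a clear loss of inhibition in this assay. Compound 3 is built on a different core from compound 1; the difference between the two cores is not broken down here. Among the three, compound 3 stands highest.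

Compound 4 `COC(=O)CNC(=O)c1ccc(C(=O)NC[C@H]2COc3ccccc3O2)cc1-c1ccccc1OC` has not yet been tested in this assay. It differs from compound 3 by methoxy in place of methyl on an aromatic carbon, at the same place as in the earlier pair, so it is the same change applied to the other core. Since the change gave a 50-fold higher number from compound 1 to compound 2 (1.70 log units; beyond the scatter), a step in the same direction is expected, an 18-fold higher number from compound 3 to compound 4 (1.25 log units; beyond the scatter), though its size may differ on this core. Compound 3 already gives 113000 nM, the highest number of the three. Compound 4 is estimated at 2000000 nM, within 300000 nM to 10000000 nM.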

Compound 4, half-maximal inhibitory concentration: 122000 nM
For compound 4 the middle estimate is 16-fold (1.21 log units) above the measured one; the measured number lies below the stated range.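

On the core of compound 3, putting methoxy in place of methyl gave a 1.1-fold higher number from compound 3 to compound 4 (0.03 log units; within the scatter) in this assay, so no effect of the swap can be read on this core. The size of the step therefore did not carry over from one core to the other, and a result from one core was a poor guide to the other in this series: the same change on two cores in this assay, a 50-fold higher number (1.70 log units; beyond the scatter) from compound 1 to compound 2 and a 1.1-fold higher number (0.03 log units; within the scatter) from compound 3 to compound 4, 46-fold (1.67 log units) apart, beyond the scatter of two such steps
This does not show why the two cores respond differently, and two pairs cannot say how any other change, or this change on any further core, would behave.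

The compounds shown leave open how a chlorine, a fluorine or an ethoxy group in the same place would behave on each core, and whether the two cores would part in the same way with those groups. They also leave open what a carboxylic acid in place of the methyl ester would do on either core.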